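Morpholine amide in place of primary amide

This account rests on a few compounds, and the source may have more. Where it says the series, first, only, none or still open, it means among the compounds named here.

Measured compounds in a physicochemical assay for lipophilicity; a lower number here means a more polar compound, a higher number a more lipophilic compound:
compound 1 `CC[C@H](C)[C@H](NC(=O)[C@H](CC(=O)O)NC(=O)CCCOc1ccc(C(=N)N)cc1)C(=O)O` gives 1.47
compound 2 `CCc1ccc(OCCNC(=O)C(CC(=O)O)NC(=O)CCCOc2ccc(C(=N)N)cc2)cc1` gives 1.95
compound 3 `CC(C)[C@H](NC(=O)[C@H](CC(=O)O)NC(=O)CCCOc1ccc(C(=N)N)cc1)C(N)=O` gives 0.891

Compound 3 stands lowest of the three numbers in this assay. Within the data shown here, the one step in hand, a number 0.58 log units lower from compound 1 to compound 3 (beyond the scatter), lies beyond the scatter and sets compound 3 below compound 1; compound 2 stands furthest from compound 3, also beyond the scatter.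

Compound 4 `CC(C)[C@H](NC(=O)[C@H](CC(=O)O)NC(=O)CCCOc1ccc(C(=N)N)cc1)C(=O)N1CCOCC1` differs from compound 3 in one place: morpholin-4-yl in place of amino on a carbonyl carbon. Among the measured compounds shown here, no measured step covers this kind of change; the step from compound 1 to compound 3 swaps a carboxy group for a carbamoyl group together with a change in the alkyl, so it gives no direct guide. What is counted in the change is a loss of one hydrogen-bond donor and a gain of four carbons, one nitrogen and one oxygen in a ring. On that basis a modest rise in this assay is expected, the estimated step being a number 0.41 log units higher from compound 3 to compound 4 (beyond the scatter), near the edge of the scatter. Compound 4 is therefore estimated at 1.3, with a range from 0.9 to 1.7.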

Compound 4, partition coefficient: 0.716
Compound 4: middle estimate off by 0.58 log units, on the high side, outside the stated range (below it).
By their numbers in this assay, from the lowest: compounds 4 and 3 (each within the scatter of the next); then compound 1; then compound 2.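

At this carbonyl carbon, morpholin-4-yl in place of amino gives a number 0.18 log units lower from compound 3 to compound 4 (within the scatter) in this assay and so leaves the two compounds unseparated, although the entering group brings a six-membered non-aromatic ring and no hydrogen-bond donor. The separation from compound 1 persists with either group: the change on the amide-type nitrogen gives a number 0.58 log units lower from compound 1 to compound 3 (beyond the scatter) for the carbamoyl compound and a number 0.75 log units lower from compound 1 to compound 4 (beyond the scatter) for the morpholine amide in this assay on the same scale. No evidence in hand bears on this result.

The step from compound 1 still joins two changes, and 1-carboxy-2-methylpropyl on the amide-type nitrogen would part the carboxylic acid from the alkyl difference. Going by these compounds, whether piperidin-1-yl or dimethylamino on this carbonyl carbon would also stay with compound 3 remains open.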